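Extending the 1H-pyrazol-1-yl Group of Compound 1

A few compounds are considered here, and "the series" means these few. Any claim that something is new, unique, unknown or untested is made for them only; others in the source may bear on it.

For the measured compounds named here, compound 1 `C[C@@H]1CN(c2sc(C(F)(F)F)nc2-c2nc3ccccc3[nH]2)CCN1C(=O)Cn1cccn1` stands at the lower of the two numbers measured so far in a functional assay on CHO-K1 cells for antagonist activity at C-X-C chemokine receptor type 3 (Homo sapiens), read by FLIPR, with a stated time of 10 min, in the presence of a further agent that is not named here; on this read-out higher numbers stand for weaker inhibition and lower numbers for stronger inhibition: compound 1 gives 13 nM. Going by the values given here, its only measured neighbour is compound 2 `C[C@@H]1CN(c2sc(C(F)(F)F)nc2-c2nc3ccccc3n2C)CCN1C(=O)Cn1cccn1`, which in this assay gives 110 nM; the step of an 8.5-fold higher number from compound 1 to compound 2 (0.93 log units; beyond the scatter) follows methyl in place of hydrogen on an aromatic nitrogen.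

Compound 3 `C[C@@H]1CN(c2sc(C(F)(F)F)nc2-c2nc3ccccc3[nH]2)CCN1C(=O)Cn1cc(C2CCN(C)CC2)cn1` leaves that aromatic nitrogen as it is in compound 1 and differs at another site: 1-methylpiperidin-4-yl in place of hydrogen on an aromatic carbon. Among the compounds with values here, the one measured step in this set concerns a different part of the molecule, so no measured step bears directly on this change, and its size is not known from the data. In the absence of any precedent, the step of a 1.2-fold higher number from compound 1 to compound 3 (0.06 log units; within the scatter) is expected to be small, possibly within the scatter, and its direction is uncertain. Compound 3 is therefore expected to give about 15 nM in this assay, with a wide range from 4 nM to 60 nM reflecting that uncertainty.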

Compound 3, half-maximal inhibitory concentration: 15 nM
Beside the measured number, compound 3's estimate shows no gap at the digits printed; low and high end bracket the measured number.
By their numbers in this assay, from the lowest: compounds 1 and 3 (each within the scatter of the next); then compound 2.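

In this assay, the step of a 1.2-fold higher number from compound 1 to compound 3 (0.06 log units; within the scatter) shows that the aromatic carbon of the five-membered ring, two ring bonds from the ring nitrogen, can carry a 1-methylpiperidin-4-yl group without a change beyond the scatter. This group adds 7 heavy atoms, including a six-membered non-aromatic ring, so the 1H-pyrazol-1-yl end of compound 1 can be extended considerably while the read-out holds; the earlier step, by contrast, concerned only an aromatic nitrogen elsewhere in the molecule. No supporting measurement is available to explain why the number holds at this position.

The compounds shown leave open whether this tolerance belongs to the 1-methylpiperidin-4-yl group alone or extends to other groups at the same carbon, such as a carboxylic acid, a simple open-chain amine or a longer alkyl chain. They also leave open whether the methyl on the piperidine nitrogen matters, which a comparison with the unsubstituted piperidin-4-yl group or an N-acetyl version would test.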